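Lengthening the propyl chain to butyl

A few compounds are considered here, and "the series" means these few. Any claim that something is new, unique, unknown or untested is made for them only; others in the source may bear on it.

Compound 1 `CCc1cnc(OCC(C)(C)O)c(-c2ccc(S(C)(=O)=O)cc2)c1`: 0.0533 h
Compound 2 `CCCOc1nc(OCC(C)(C)O)c(-c2ccc(S(C)(=O)=O)cc2)cc1CO`: 0.05 h

In an ADME assay on cells (Hepatocyte, Mus musculus) for metabolic stability (a lower number here means that the compound disappears faster, a higher number that the compound lasts longer), compound 2 gives 0.05 h, which lies within the usual scatter of compound 1 at 0.0533 h. Compound 3 `CCCCOc1nc(OCC(C)(C)O)c(-c2ccc(S(C)(=O)=O)cc2)cc1CO` differs from compound 2 by a single change, (methyl in place of hydrogen on a saturated chain carbon, three bonds along the chain from an oxygen on an aromatic ring), which reads as propyl to butyl. Among the measured compounds shown here, no measured pair shows a step of this kind, so the data offer no guide to its size. The expected no change at the digits printed from compound 2 to compound 3 (within the scatter) is therefore none beyond the scatter, in either direction. The estimated half-life of compound 3 is 0.05 h, with an expected range from 0.025 h to 0.1 h.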

Compound 3, half-life: 0.0317 h
The estimate for compound 3 lay 1.6-fold (0.20 log units) above the measured number; low and high end bracket the measured number.
By their numbers in this assay, from the lowest: compounds 3, 2 and 1 (each within the scatter of the next).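

Lengthening propyl to butyl gives the first measured step at this position: in this assay it is a 1.6-fold lower number from compound 2 to compound 3 (0.20 log units; within the scatter) and so shows no clear effect of adding methyl at this place. One step cannot show whether the half-life responds to chain length here. Nothing available explains the measured values.

From the compounds shown here alone, whether a longer chain such as pentyl or a branched chain such as isobutyl would move the half-life beyond the scatter remains open. So does the outcome of ending the chain in an amine or a carboxylic acid.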